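This account rests on a few compounds, and the source may have more. Where it says the series, first, only, none or still open, it means among the compounds named here.

Working notes on the series. Compound 1 `CSc1ccc(F)cc1NCC1=NCCN1` gives 115 nM in an assay on CHO cells for binding affinity to Alpha-2C adrenergic receptor (Homo sapiens), read by radioligand binding; a lower number here means a stronger inhibitor, a higher number a weaker inhibitor. Among the measured compounds shown here, compound 2 `CSc1ccc(C)cc1NCC1=NCCN1` changes one aromatic substituent and in this assay gives 200 nM; the step of a 1.7-fold higher number from compound 1 to compound 2 (0.24 log units; within the scatter) is the only single-point change measured so far. Compound 3 `CS(=O)(=O)c1ccc(C(F)(F)F)cc1NCC1=NCCN1` carries a methylsulfonyl group and a trifluoromethyl group. For compound 3 the result in this assay is a limit, < 5020 nM, not a number, and so its place among the shown values stays open (the limit of < 5020 nM in this assay, at which 1 of the 3 values shown sits). For the measured compounds named here, no step can be drawn from compound 3 to compound 1 or compound 2.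

Compound 4 `CSc1ccc(C(F)(F)F)cc1NCC1=NCCN1` is the next to be measured. It differs from compound 3 in one place: methylsulfanyl in place of methylsulfonyl on an aromatic carbon. Going by the values given here, no measured step covers this exchange; the one measured step, from compound 1 to compound 2, alters a different position and lies within the scatter, so it gives no direction for the present change. Compound 4 carries the same methylsulfanyl group as compound 1, which gave 115 nM, and as compound 2, which gave 200 nM. Compound 4 is therefore expected in this assay near those values, estimated at 300 nM with a range of 80 nM to 1200 nM. The implied step that the limit leaves unreadable from compound 3 to compound 4 is expected to run toward a stronger value than the limit.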

Compound 4, inhibition constant: 603 nM
For compound 4 the middle estimate is 2.0-fold (0.30 log units) below the measured one; the measured number falls inside the stated range.
By their numbers in this assay, from the lowest: compounds 1 and 2 (each within the scatter of the next); then compound 4.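

Among the compounds shown here, the aromatic position that carries fluoro in compound 1 and methyl in compound 2 now shows a change beyond the scatter for the first time: in this assay, trifluoromethyl at this position gives a 3.0-fold higher number from compound 2 to compound 4 (0.48 log units; beyond the scatter) and a 5.2-fold higher number from compound 1 to compound 4 (0.72 log units; beyond the scatter). With the methylsulfanyl group held fixed, the position therefore does not treat all three substituents alike, as the step between fluoro and methyl, which lay within the scatter, could not show; trifluoromethyl gives a weaker inhibitor than either of the other two, a reading that rests on these three compounds alone. Compound 3 gives only a limit, not a number, so the exchange of methylsulfonyl for methylsulfanyl, the one step that would isolate this change, cannot be read: the limit of < 5020 nM in this assay, at which 1 of the 4 values shown sits.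

The compounds shown leave open how far methylsulfonyl itself shifts the value with fluoro or methyl kept in place, and whether a chloro, methoxy or amine group at the trifluoromethyl position would stay close to compound 1 or move as far as compound 4. They also leave open whether an ethylsulfanyl group or a longer chain could replace methylsulfanyl on the same ring.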